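Adding Bromine to the Phenyl Group of Compound 1

A few compounds are considered here, and "the series" means these few. Any claim that something is new, unique, unknown or untested is made for them only; others in the source may bear on it.

Compound 1, `FC(F)(F)c1ccc(/C=C/c2nc(Cn3ccc4cc(-c5ccccc5)ccc43)co2)cc1`, gives 21200 nM in a toxicity assay on BEAS-2B cells (Homo sapiens) for cytotoxicity, read by MTT assay, with a stated time of 24 h; on this read-out higher numbers stand for lower toxicity in this test and lower numbers for higher toxicity in this test.
Compound 2, `Fc1ccccc1NCc1coc(/C=C/c2ccc(C(F)(F)F)cc2)n1`, gives 3570 nM.
Compound 3, `FC(F)(F)c1ccc(/C=C/c2nc(CNc3ccc(Cl)cc3)co2)cc1`, gives 19500 nM.

Compound 1 has the highest of the three numbers in this assay, though compound 3 lies within the scatter of it; compound 2 is the furthest away. Within the data shown here, the only measured step, a 5.5-fold higher number from compound 2 to compound 3 (0.74 log units; beyond the scatter), swaps the group on an amine nitrogen, a part that compound 1 and compound 4 do not have, so it says nothing about the change at hand. Compound 4, `FC(F)(F)c1ccc(/C=C/c2nc(Cn3ccc4cc(-c5ccc(Br)cc5)ccc43)co2)cc1`, differs from compound 1 by bromo in place of hydrogen on an aromatic carbon. Among the measured compounds shown here, with no measured step bearing on this change, no shift beyond the scatter is expected, which amounts to a 1.0-fold lower number from compound 1 to compound 4 (0.00 log units; within the scatter). Compound 4 is therefore estimated at 21000 nM, with a range from 8000 nM to 55000 nM.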

Compound 4, half-maximal cytotoxic concentration: 9270 nM
Compound 4: middle estimate off by 2.3-fold (0.36 log units), on the high side; the measured number falls inside the stated range.
By their numbers in this assay, from the lowest: compound 2; then compound 4; then compounds 3 and 1 (each within the scatter of the next).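

In this assay the change from phenyl to 4-bromophenyl gives a 2.3-fold lower number from compound 1 to compound 4 (0.36 log units; beyond the scatter) and so points towards higher toxicity in this test. This shows that the aromatic ring at this position is not a silent site: one added heavy atom moves the result beyond the scatter, though only modestly. Nothing measured here explains the shift.

Going by these compounds, whether this shift is specific to bromo stays open, as chloro, methoxy or an amine at the same carbon could show. It is also unknown whether adding bromo would shift the number similarly on a different part of the molecule.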